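Cytotoxicity in BJ cells: from carbamate to trifluoroacetamide

The source may report more compounds than this note shows. Statements on the series, on what has been measured and on what is new or still open speak of the compounds shown alone.

Compound 1 `CCN(CC)C(=O)COc1cc2c(-n3nc(-c4ccccn4)nc3N)ncnc2cc1OC` and compound 2 `CCCCCCOC(=O)NCCCOc1cc2c(-n3nc(-c4ccccn4)nc3N)ncnc2cc1OC` share one core and differ in the side chain on the ether oxygen. In an ADME assay on BJ cells (Homo sapiens) for cytotoxicity, with a stated time of 72 h (a higher number here means that more compound is needed for the effect, a lower number that less compound is needed), compound 1 gives only a limit, > 25000 nM. For compound 2 this assay reports "not determined" (no result reported), so no number exists for it. Among the two measured compounds the only value shown is the limit at which compound 1 sits, (the limit of > 25000 nM in this assay, at which 1 of the 2 values shown sits). Compound 3 `COc1cc2ncnc(-n3nc(-c4ccccn4)nc3N)c2cc1OCCCNC(=O)C(F)(F)F` is the untested neighbour of compound 2: trifluoromethyl in place of hexyloxy on a carbonyl carbon. Going by the values given here, no measured step between these compounds is available, so the size of the change from compound 2 to compound 3 in this assay cannot be read from the data; no shift beyond the usual scatter is expected in either direction. For compound 3 the estimated half-maximal effective concentration in this assay is 25000 nM, within an expected range of 10000 nM to 50000 nM, most likely again reported as a limit.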

Compound 3, half-maximal effective concentration: > 7000 nM
Compound 3: no number, only a limit (the forecaster's own chance of this, stated with the estimate: 70%); the middle value is on the limit's open side.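

In this assay compound 3 gives only a limit, > 7000 nM. Compound 1 likewise gives only a limit, > 25000 nM. Going by these compounds alone, no step from compound 1 to compound 3 can be read from these two limits. The compounds shown leave open where the actual half-maximal effective concentration of either compound lies.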